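The source may hold more compounds than are shown below. What is called first, only, known or untested is meant among the compounds shown, and "the series" means these compounds.

Compound 1 `CCCc1nc(C)c2c(C)nn(CCC)c(=O)n12` — in a functional assay for inhibition, with Homo sapiens as the target (a lower number here means a stronger inhibitor, a higher number a weaker inhibitor), compound 1 gives > 48000 nM, which is a limit of the assay and not a number.
Compound 2 `Cc1nc(-c2ccccc2)n2c(S)nncc12` — in this assay compound 2 gives > 48000 nM, again only a limit.

Compound 1 therefore stands at the edge of what this assay can report, where both values sit (the limit of > 48000 nM in this assay, at which 2 of the 2 values shown sit). Compound 3 `C=C=Cn1nc(C)c2c(C)nc(CCC)n2c1=O` differs from compound 1 in one place: propa-1,2-dien-1-yl in place of propyl on an aromatic nitrogen. Within the data shown here, no measured pair shows what such a swap does, so the step from propyl to propa-1,2-dien-1-yl is expected to be none beyond the usual scatter, a number no higher from compound 1 to compound 3 (the limit leaves the size open). Compound 3 is thus expected to give about 48000 nM, between 15000 nM and 150000 nM, most likely reported again as a limit.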

Compound 3, half-maximal inhibitory concentration: > 48000 nM
Compound 3 gave a limit, no number (the forecaster's own chance of this, stated with the estimate: 85%); the middle value sits exactly at the limit.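

Compound 1 and compound 3 both stop at a limit of this assay and give no number, so no step between them can be read: the limit of > 48000 nM in this assay, at which 3 of the 3 values shown sit.

The compounds shown leave open whether swapping propyl for propa-1,2-dien-1-yl changes inhibition at all.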